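The compounds below may be only part of what the source reports. "The series", "measured", "known", "first", "only" and "open" are said of these compounds alone.

Of the compounds shown here, two built on a shared core have been measured in a functional assay on NCI-H1581 cells (Homo sapiens) for antiproliferative activity, read by CCK-8 assay, with a stated time of 72 h; on this read-out lower numbers stand for stronger inhibition and higher numbers for weaker inhibition. Compound 1 `COc1cc(OC)c(Cl)c(-c2ccc3c(NC(=O)c4ccc(N5CCCN(C)CC5)cc4)n[nH]c3n2)c1Cl` gives 1.3 nM in this assay. Compound 2 `COc1cc(OC)c(Cl)c(-c2ccc3c(NC(=O)c4ccc(N5CCN(C)CC5)nc4)n[nH]c3n2)c1Cl` gives 1.5 nM in this assay. The two numbers lie within the usual scatter of each other, so on what has been measured compound 1 cannot be set apart from compound 2, and no ranking between them is claimed.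

Compound 3 `COc1cc(OC)c(Cl)c(-c2ccc3c(NC(=O)c4ccc(N)cc4)n[nH]c3n2)c1Cl` has not yet been measured. It differs from compound 1 in one place: amino in place of 4-methyl-1,4-diazepan-1-yl on an aromatic carbon. For the measured compounds named here, no pair of measured compounds differing in this one place exists, and compound 2 differs from compound 1 in more than one place, so the two measured values give no direct guide to the size of this change. The remainder of the molecule is unchanged. The expectation is that a 4.6-fold higher number from compound 1 to compound 3 (0.66 log units; beyond the scatter) will be a loss beyond the scatter, though a moderate one. Compound 3 is therefore estimated at 6 nM, with a likely range from 1.5 nM to 30 nM.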

Compound 3, half-maximal inhibitory concentration: 218 nM
The estimate for compound 3 lay 36-fold (1.56 log units) below the measured number, and the stated range ends below it.
By their numbers in this assay, from the lowest: compounds 1 and 2 (each within the scatter of the next); then compound 3.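

In this assay, the step of a 170-fold higher number from compound 1 to compound 3 (2.22 log units; beyond the scatter) is large and beyond the scatter, and it shows that activity depends strongly on what sits on this aromatic carbon, para to a large group. Compound 1 and compound 3 differ only here, so the entire loss goes with this single exchange, in which 4-methyl-1,4-diazepan-1-yl, with its seven-membered non-aromatic ring and 8 heavy atoms, gives way to amino, with 1 heavy atom and no ring. No supporting evidence bears on why the exchange costs so much, and the step itself records only its size.

The compounds shown leave open which part of 4-methyl-1,4-diazepan-1-yl matters, whether that is the ring, the methyl-bearing nitrogen or simply the size of the group. Groups such as dimethylamino, piperidin-1-yl or morpholin-4-yl at this place, or an open chain ending in an amine, would help separate these possibilities and show how much of the activity of compound 1 can be kept with a smaller group.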